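The source may hold more compounds than are shown below. What is called first, only, known or untested is meant among the compounds shown, and "the series" means these compounds.

Working notes on the series. Compound 1 `CCN(CC)S(=O)(=O)c1ccc(S(=O)(=O)N2CCC[C@@H](C(=O)NC3CN(C(=O)OC(C)(C)C)C3)C2)cc1` in a functional assay on MIA PaCa-2 cells (Homo sapiens) for inhibition, read by MTT assay, with a stated time of 3 days (a higher number here means a weaker inhibitor, a lower number a stronger inhibitor), gives 100 nM, the higher of the two numbers recorded so far. Compound 2 `CC(C)c1noc(N2CCN(C(=O)[C@@H]3CCCN(S(=O)(=O)c4ccc(S(=O)(=O)C(C)C)cc4)C3)CC2)n1` in this assay gives 30 nM, a gap from compound 1 that lies beyond the scatter. Compound 3 `CCOC(=O)[C@@H]1CCCN(S(=O)(=O)c2cccc(S(=O)(=O)N(CC)CC)c2)C1` in this assay returns only a limit, > 10000 nM, which is the limit of > 10000 nM in this assay, at which 1 of the 3 values shown sits. Compound 4 `CCN(CC)S(=O)(=O)c1ccc(S(=O)(=O)N2CCC[C@@H](C(=O)NC)C2)cc1` is not yet measured; it differs from compound 1 by methyl in place of 1-(tert-butoxycarbonyl)azetidin-3-yl on an amide-type nitrogen. Among the measured compounds shown here, no measured pair isolates a change at this amide nitrogen, so the direction rests on the two numbers alone: both compound 1 and compound 2 carry a larger group there, and compound 4 carries only methyl. The step from compound 1 to compound 4 is therefore expected to be a loss, a 6.0-fold higher number from compound 1 to compound 4 (0.78 log units; beyond the scatter). Compound 4 is expected to give about 600 nM, plausibly between 150 nM and 3000 nM.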

Compound 4, half-maximal inhibitory concentration: 2000 nM
Estimate against measurement, compound 4: 3.3-fold (0.52 log units) below; the range from low to high includes it.
By their numbers in this assay, from the lowest: compound 2; then compound 1; then compound 4. At a limit, above all of these: compound 3.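

Among the compounds shown here, replacing 1-(tert-butoxycarbonyl)azetidin-3-yl with methyl on the amide-type nitrogen gives a 20-fold higher number from compound 1 to compound 4 (1.30 log units; beyond the scatter) in this assay, the first measured pair to isolate this position. The outgoing group therefore matters substantially to the read-out here, although the shared core retains some activity without it. With only methyl at this place, compound 4 still returns a number and not a limit: the limit of > 10000 nM in this assay, at which 1 of the 4 values shown sits.

As far as these compounds go, whether the difference rests on the four-membered ring or on the tert-butoxycarbonyl group remains open. A free azetidin-3-yl amine or a longer alkyl chain at this nitrogen would help separate the two.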